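Acylhydrazone series: the para chloro of compound 2 removed

A few compounds are considered here, and "the series" means these few. Any claim that something is new, unique, unknown or untested is made for them only; others in the source may bear on it.

Of the compounds shown here, two carry numbers so far. Compound 1 `COc1ccc(OC)c(/C=C/c2nnc(Nc3ccc(Cl)cc3)o2)c1` gives 6150 nM in a functional assay on SF-295 cells (Homo sapiens) for antiproliferative activity, read by sulforhodamine B assay, with a stated time of 48 h; a lower number here means a stronger inhibitor of growth, a higher number a weaker inhibitor of growth. Compound 2 `COc1ccc(OC)c(/C=C/C(=O)N/N=C/c2ccc(Cl)cc2)c1` gives 129 nM in this assay, the lowest of the two numbers; its nearest neighbour is compound 1, whose number stands higher by a gap beyond the scatter. Going by the values given here, no measured pair differs in a single place, so no step size is yet known.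

Compound 3 `COc1ccc(OC)c(/C=C/C(=O)N/N=C/c2ccccc2)c1` is the next compound to be measured in this assay. Its difference from compound 2 is hydrogen in place of chloro on an aromatic carbon, para to a large group; cut one bond further out, the same difference reads 4-chlorophenyl to phenyl. The two measured compounds differ in several places at once, so the weight of this single change cannot be read from them. For the step from compound 2 to compound 3 a small move toward a higher number is expected, a 1.9-fold higher number from compound 2 to compound 3 (0.29 log units; within the scatter), not certain to lie beyond the scatter. Compound 3 is estimated at 250 nM in this assay, with a range of 80 nM to 800 nM.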

Compound 3, concentration for 50% growth inhibition: 1000 nM
Compound 3: middle estimate off by 4.0-fold (0.60 log units), on the low side; the measured number lies above the stated range.
By their numbers in this assay, from the lowest: compound 2; then compound 3; then compound 1.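

Going by these compounds alone, the step of a 7.8-fold higher number from compound 2 to compound 3 (0.89 log units; beyond the scatter) is the first single-change measure: in this assay, replacing chloro with hydrogen on the aromatic carbon, para to a large group, moves the number beyond the scatter. This position therefore matters to growth inhibition, and the rest of the structure of compound 2 does not alone account for its 129 nM, since compound 3 keeps all of that structure and differs only by this one atom. The data give no measured basis for explaining the size of this step.

As far as these compounds go, whether chloro is particular here, or whether another group on the same carbon would serve equally well, remains open; fluoro, methoxy, dimethylamino or a carboxylic acid at this position would begin to answer that. Also open, from the compounds shown here alone, is whether 4-chlorophenyl to phenyl gives a step of similar size on the core of compound 1, which would need its own single-change pair.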